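The compounds below may be only part of what the source reports. "The series", "measured", "known", "first", "only" and "open" are said of these compounds alone.

Values so far in a physicochemical assay for lipophilicity; a lower number here means a more polar compound, a higher number a more lipophilic compound

Compound 1 `Cn1nccc1-c1cc(C(F)(F)F)ccc1[C@H]1CCOc2cc(S(=O)(=O)Nc3nccs3)ccc21` gives 2.2
Compound 2 `O=S(=O)(Nc1nccs1)c1ccc2c(c1)OCC[C@@H]2c1ccc(C(F)(F)F)cc1N1CCNCC1` gives 1.4
Compound 3 `O=S(=O)(Nc1nccs1)c1ccc2c(c1)OCC[C@@H]2c1ccc(C(F)(F)F)cc1-c1nccs1` gives 3.3

Compound 3 stands highest of the three, clearly beyond the scatter from both others. Compound 4 `O=S(=O)(Nc1nccs1)c1ccc2c(c1)OCC[C@@H]2c1ccc(C(F)(F)F)cc1-c1ccc(F)nc1` differs from it in one place, on an aromatic carbon ortho to a large group: 6-fluoropyridin-3-yl in place of 1,3-thiazol-2-yl on an aromatic carbon. Two measured steps lead to the same 1,3-thiazol-2-yl group. One is large, a number 1.10 log units higher from compound 1 to compound 3 (beyond the scatter), and so is the other, a number 1.90 log units higher from compound 2 to compound 3 (beyond the scatter). The first also swaps one aromatic ring for another, so it is the closer guide, and it shows that such a swap can matter. Among the compounds with values here, no measured compound carries 6-fluoropyridin-3-yl, which leaves the direction uncertain. The expected change is small, a number 0.10 log units higher from compound 3 to compound 4 (within the scatter), and not beyond the scatter. Compound 4 is estimated at 3.4, with an expected range from 2.9 to 3.9.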

Compound 4, distribution coefficient: 3.2
Beside the measured number, compound 4's estimate is 0.20 log units above it; low and high end bracket the measured number.
By their numbers in this assay, from the lowest: compound 2; then compound 1; then compounds 4 and 3 (each within the scatter of the next).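

In this assay, a six-membered aromatic ring, 6-fluoropyridin-3-yl, can take the place of the five-membered 1,3-thiazol-2-yl with a step inside the scatter, a number 0.10 log units lower from compound 3 to compound 4 (within the scatter). Not every aromatic swap on this carbon behaves this way, since 1-methyl-1H-pyrazol-5-yl stands clearly apart, a number 1.00 log units higher from compound 1 to compound 4 (beyond the scatter), and the non-aromatic piperazin-1-yl lies further off still, a number 1.80 log units higher from compound 2 to compound 4 (beyond the scatter). Nothing measured here explains these differences. The part played by the fluorine of 6-fluoropyridin-3-yl remains open, since no compound shown carries the same ring without it. Going by these compounds, how a carboxylic acid or an open-chain amine would read on this carbon also remains open.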